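This account rests on a few compounds, and the source may have more. Where it says the series, first, only, none or still open, it means among the compounds named here.

Measured so far in a functional assay on the whole organism (stomach) for inhibition, with Rattus norvegicus as the target, with a stated time of 15 min, at a dose of 5 mg/kg by the intravenous route; a lower number here means less inhibition, a higher number more inhibition at the dose given (going by the name of the read-out):
Compound 1, `CN(C)CCCOc1ccccc1CCC1CCCCC1`, gives 42%.
Compound 2, `CCN(CC)CCCOc1ccccc1CCC1CCCCC1`, gives 66%.
Compound 3, `CN1CCCCC1COc1ccccc1CCC1CCCCC1`, gives 100%.

Compound 3 stands highest of the three; its nearest neighbour, compound 2, sits a number 34 percentage points higher from compound 2 to compound 3 (beyond the scatter), and compound 1 further still, a number 58 percentage points higher from compound 1 to compound 3 (beyond the scatter). Compound 4, `CCN1CCCC(COc2ccccc2CCC2CCCCC2)C1`, is not yet measured. It differs from compound 3 in one place: 1-ethylpiperidin-3-yl in place of 1-methylpiperidin-2-yl on a saturated chain carbon bound to an oxygen on an aromatic ring. Within the data shown here, no measured step swaps one ring amine for another, so only indirect hints exist. The step of a number 24 percentage points higher from compound 1 to compound 2 (beyond the scatter) shows that a larger amine substituent went with a higher number, and both ring-amine steps were large upward. Compound 4 is therefore expected to stay near compound 3, with a small downward step at most, a number 15 percentage points lower from compound 3 to compound 4 (beyond the scatter). Compound 4 is estimated at 85%, between 55% and 100%.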

Compound 4, a percentage reported as inhibition, in the whole organism at one dose (the size of the read-out at that dose, not a potency): 57%
Estimate against measurement, compound 4: 28 percentage points above; low and high end bracket the measured number.
By their numbers in this assay, from the lowest: compound 1; then compounds 4 and 2 (each within the scatter of the next); then compound 3.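

In this assay, one ring amine cannot stand in for another: 1-ethylpiperidin-3-yl in place of 1-methylpiperidin-2-yl gives a number 43 percentage points lower from compound 3 to compound 4 (beyond the scatter), so a ring amine alone does not secure the high number. Set against the open-chain amines, the same group gives a number 9 percentage points lower from compound 2 to compound 4 (within the scatter) and a number 15 percentage points higher from compound 1 to compound 4 (beyond the scatter). No measurement here accounts for these steps.

From the compounds shown here alone, this step changes both the group on the ring nitrogen and the point of attachment, so their separate shares stay open. A 1-methylpiperidin-3-yl or 1-ethylpiperidin-2-yl group would tell them apart.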